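A few compounds are considered here, and "the series" means these few. Any claim that something is new, unique, unknown or untested is made for them only; others in the source may bear on it.

Measured in a functional assay on A549 cells (Homo sapiens) for inhibition, read by MTT assay, with a stated time of 72 h; a higher number here means a weaker inhibitor, a lower number a stronger inhibitor:
- Compound 1 `COc1ccc(-c2cc(C(=O)N3CCC4(CC3)CC(=O)c3nn(C(C)(C)C)cc3O4)c3ccccc3n2)cc1`: 3740 nM
- Compound 2 `CN(C)c1ccc(-c2cc(C(=O)N3CCC4(CC3)CC(=O)c3nn(C(C)(C)C)cc3O4)c3ccccc3n2)cc1`: 1150 nM

Of these two, compound 2 has the lower number, at 1150 nM, which makes it the stronger inhibitor. Among the measured compounds shown here, compound 3 `COc1cc(C(=O)N2CCC3(CC2)CC(=O)c2nn(C(C)(C)C)cc2O3)c2ccccc2n1` has no measurement yet. Its difference from compound 2 is methoxy in place of 4-(dimethylamino)phenyl on an aromatic carbon, next to the ring nitrogen.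

For the measured compounds named here, only one measured step bears on this, and only indirectly. That step is a 3.3-fold lower number from compound 1 to compound 2 (0.51 log units; beyond the scatter), made by changing a single group on the aromatic ring that compound 3 lacks altogether. Going by the values given here, no measured compound lacks that ring, so the direction is a judgement and the uncertainty is wide. A move towards weaker inhibition, somewhat larger than that step, seems most likely. The estimated change in this assay is a 6.1-fold higher number from compound 2 to compound 3 (0.78 log units; beyond the scatter). Compound 3 is expected at about 7000 nM, with an estimated range of 2000 nM to 25000 nM.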

Compound 3, half-maximal inhibitory concentration: > 10000 nM
Compound 3 was reported as a limit (the forecaster's own chance of this, stated with the estimate: 15%); middle value at least 1.4-fold (0.15 log units) from the limit.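

On this aromatic carbon, methoxy in place of 4-(dimethylamino)phenyl gives an at least 8.6-fold higher number from compound 2 to compound 3 (0.93 log units; beyond the scatter), and methoxy in place of 4-methoxyphenyl gives an at least 2.6-fold higher number from compound 1 to compound 3 (0.42 log units; beyond the scatter). The earlier pair varied only a group on the six-membered aromatic ring of carbon only, whereas these two steps remove that ring, and both move towards weaker inhibition in this assay. The reading for compound 3 is a limit and not a number, so the full size of both steps stays open, because its value sits at that limit: the limit of > 10000 nM in this assay, at which 1 of the 3 values shown sits.

Going by these compounds, what remains open is whether losing the ring or bringing in methoxy matters more, as both happen in the same change. An unsubstituted phenyl or a small amine at this carbon would help to separate the two.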